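The compounds below may be only part of what the source reports. "The series", "measured", "known", "first", "only" and "open" are said of these compounds alone.

In a physicochemical assay for lipophilicity, using the shake flask method, at pH 7.4 (on this read-out higher numbers stand for higher lipophilicity and lower numbers for lower lipophilicity), compound 1 (`CCCC(Oc1ccc(-n2cc3ccccc3n2)cc1)c1ccc(C(=O)NCCC(=O)O)cc1`) gives 2.5 and compound 2 (`CCCC(Oc1ccc(-n2cc(C(F)(F)F)c(C)n2)cc1)c1ccc(C(=O)NCCC(=O)O)cc1`) gives 2.8, and these two values lie within the scatter of each other. Compound 3 (`CCCC(Oc1ccc(-n2cc3c(n2)CCCC3)cc1)c1ccc(C(=O)NCCC(=O)O)cc1`) has not yet been measured. Its structure differs from that of compound 2 in one place: a group of 9 heavy atoms (7 carbon, 2 nitrogen; one five-membered aromatic ring with 2 hetero atoms, one six-membered non-aromatic ring of carbon only) in place of a group of 10 heavy atoms (5 carbon, 2 nitrogen, 3 fluorine; one five-membered aromatic ring with 2 hetero atoms), on an aromatic carbon. The swap sits on an aromatic carbon of a six-membered aromatic ring of carbon only, para to a large group. Among the measured compounds shown here, only one measured step bears on it, an exchange at that same carbon, where 3-methyl-4-(trifluoromethyl)-1H-pyrazol-1-yl takes the place of 2H-indazol-2-yl: a number 0.30 log units higher from compound 1 to compound 2 (within the scatter). With that single step as a guide, no change beyond the scatter is expected in this assay. The expected step is small, a number 0.20 log units lower from compound 2 to compound 3 (within the scatter). For compound 3 the estimated value is 2.6, with an expected range from 2.2 to 3.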

Compound 3, distribution coefficient: 2.7
For compound 3 the middle estimate is 0.10 log units below the measured one, and the stated range covers the measured number.
By their numbers in this assay, from the lowest: compounds 1, 3 and 2 (each within the scatter of the next).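

In this assay, exchanging the 3-methyl-4-(trifluoromethyl)-1H-pyrazol-1-yl group for one that carries a six-membered non-aromatic ring of carbon only gives a number 0.10 log units lower from compound 2 to compound 3 (within the scatter) on this aromatic carbon. Having that six-membered ring non-aromatic rather than aromatic gives a number 0.20 log units higher from compound 1 to compound 3 (within the scatter), so all three groups tried at this position, with or without fluorine and with either kind of six-membered ring, leave the read-out within the scatter. Nothing measured alongside these values explains why they stay so close.

On these data alone, it remains open whether a group of another kind at this carbon, such as an amine or a morpholine ring, would shift the read-out beyond the scatter. These three compounds also cannot show whether the same small steps would appear on a different core.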